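Compound 3 to compound 4: cyano in place of fluoro

A few compounds are considered here, and "the series" means these few. Any claim that something is new, unique, unknown or untested is made for them only; others in the source may bear on it.

Compound 3 (`Cc1ccc(S(=O)(=O)N[C@@H](CC(=O)NC(C)(C)C)C(=O)NCCNC(=O)c2cccc(F)c2)cc1`) stands in an ADME assay on HepG2 cells (Homo sapiens) for cytotoxicity (on this read-out higher numbers stand for an effect only at larger amounts of compound and lower numbers for an effect already at smaller amounts), at > 11000 nM as a limit of the assay, not a number. Compound 1 (`Cc1ccc(S(=O)(=O)N[C@@H](CC(=O)NC(C)(C)C)C(=O)NCCNC(=O)c2cccc(O)c2)cc1`) gives > 11000 nM as a limit too. Compound 2 (`Cc1ccc(S(=O)(=O)N[C@@H](CC(=O)NC(C)(C)C)C(=O)NCCNC(=O)Nc2ccccc2)cc1`) gives > 11000 nM as a limit as well. The series therefore offers the limit of > 11000 nM in this assay, at which 3 of the 3 values shown sit, and no measured number.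

Compound 4 (`Cc1ccc(S(=O)(=O)N[C@@H](CC(=O)NC(C)(C)C)C(=O)NCCNC(=O)c2cccc(C#N)c2)cc1`) carries cyano in place of fluoro on an aromatic carbon, meta to a large group (cyano in place of fluoro on an aromatic carbon).

The nearest measured change, fluoro in place of hydroxy on an aromatic carbon, is a step that the two limits leave unreadable from compound 1 to compound 3 and so gives no size to carry over. Anilino in place of 3-hydroxyphenyl on a carbonyl carbon gives a step that the two limits leave unreadable from compound 1 to compound 2 and 3-fluorophenyl in place of anilino gives a step that the two limits leave unreadable from compound 2 to compound 3 in the same way.

No large step is expected in this assay because compound 3 sits at > 11000 nM as a limit. The estimated step is a step that the limit leaves unreadable from compound 3 to compound 4 and no direction is expected for it. Compound 4 is expected at 15000 nM with an estimated range from 9000 nM to 30000 nM and will most likely be reported only as a limit.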

Compound 4, half-maximal effective concentration: > 11000 nM
Compound 4: a limit, no number; the forecaster's own chance of this, stated with the estimate: 85%; the middle value does not contradict the limit.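

In this assay compound 4 gives > 11000 nM, a limit of the assay and not a number. No step among compound 1, compound 2, compound 3 and compound 4 can be read, all four values being limits: the limit of > 11000 nM in this assay, at which 4 of the 4 values shown sit.

The compounds shown leave open the concentration at which any of the four has an effect in this assay, and whether cyano in place of fluoro shifts it.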